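Replacing a Fluorophenyl Arm: What Compound 3 Might Show

A few compounds are considered here, and "the series" means these few. Any claim that something is new, unique, unknown or untested is made for them only; others in the source may bear on it.

Compound 1 `O=C(NCc1ccc(CNS(=O)(=O)c2ccc(-c3ccc(F)cc3)cc2)cc1)c1ccc(F)cc1`: 100 nM
Compound 2 `O=C(NCc1ccc(CNS(=O)(=O)c2ccc3c(c2)CCO3)cc1)c1ccc(F)cc1`: 10 nM

Both compounds were tested in an assay on MDA-MB-231 cells for binding affinity to C-X-C chemokine receptor type 4 (Homo sapiens), read by fluorescence and microscopy, with stated times of 10 min and 30 min; on this read-out higher numbers stand for an effect only at larger amounts of compound and lower numbers for an effect already at smaller amounts. Of the two numbers, compound 1 holds the higher one, and its gap to compound 2 lies beyond the usual scatter, so compound 2 shows its effect already at smaller amounts. Compound 3 `O=C(NCc1ccc(CNS(=O)(=O)c2ccc(CN3CCCC3)cc2)cc1)c1ccc(F)cc1` has not yet been measured. It comes from compound 1 through a single change: (pyrrolidin-1-yl)methyl in place of 4-fluorophenyl on an aromatic carbon. Among the compounds with values here, no measured pair shows this kind of swap, so any expectation rests only on the two numbers at hand and on the structural change itself. The estimate for compound 3 is a modest step from compound 1 toward lower numbers, a 2.0-fold lower number from compound 1 to compound 3 (0.30 log units; within the scatter), and this step may well stay within the scatter. The value expected for compound 3 is 50 nM, with a range from 10 nM to 300 nM.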

Compound 3, effective concentration (reported as EC, without a stated level of effect): 1 nM
The estimate for compound 3 lay 50-fold (1.70 log units) above the measured number, and the stated range ends above it.
By their numbers in this assay, from the lowest: compound 3; then compound 2; then compound 1.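

In this assay, putting (pyrrolidin-1-yl)methyl in place of 4-fluorophenyl gives a 100-fold lower number from compound 1 to compound 3 (2.00 log units; beyond the scatter) and so counts as a large step. This shows that the group on this aromatic carbon, para to a large group, has a strong bearing on the reading. It also shows that an aromatic ring is not needed there, since a five-membered non-aromatic ring containing nitrogen gives the far lower number, though nothing measured here explains the gain.

Still open, as far as these compounds go, is whether the gain depends on the pyrrolidine ring or simply on having an amine at this place, which a dimethylaminomethyl group or a piperidin-1-ylmethyl group could help to separate. Also open, from the compounds shown here alone, is how a longer chain carrying the pyrrolidine, or a carboxylic acid at the same place, would read.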